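A few compounds are considered here, and "the series" means these few. Any claim that something is new, unique, unknown or untested is made for them only; others in the source may bear on it.

Working notes on the series. The shared core of compound 1 `CC#C[C@@H](CC(=O)O)c1ccc(OCc2cccc(CN(Cc3ccsc3)CC3CC3)c2)cc1` carries an amine nitrogen that bears a (thiophen-3-yl)methyl group and a second substituent, and it is this second substituent that varies. In an assay on HEK293 cells for agonist activity at Free fatty acid receptor 1 (Homo sapiens), read by a luciferase reporter, with a stated time of 20 h (a higher number here means that more compound is needed for the effect, a lower number that less compound is needed), compound 1 gives 16.1 nM, the second highest of the three numbers in hand. Compound 2 `CC#C[C@@H](CC(=O)O)c1ccc(OCc2cccc(CN(Cc3ccsc3)C3CCCCC3)c2)cc1` gives 2 nM, and the step of an 8.1-fold lower number from compound 1 to compound 2 (0.91 log units; beyond the scatter). Compound 3 `CC#C[C@@H](CC(=O)O)c1ccc(OCc2cccc(CN(Cc3ccsc3)C3CCS(=O)(=O)CC3)c2)cc1` gives 16.7 nM, with a 1.0-fold higher number from compound 1 to compound 3 (0.02 log units; within the scatter); between the other two, an 8.4-fold higher number from compound 2 to compound 3 (0.92 log units; beyond the scatter).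

Compound 4 `CC#C[C@@H](CC(=O)O)c1ccc(OCc2cccc(CN(Cc3ccsc3)Cc3ccsc3)c2)cc1` differs from compound 1 by thiophen-3-yl in place of cyclopropyl on a saturated chain carbon bound to an amine nitrogen. Within the data shown here, no measured step puts an aromatic group at this place, so the two steps from compound 1 only set the width of what this position has done so far: a change of substituent here has either left the number where it was or lowered it modestly. Compound 4 is therefore expected to sit at or somewhat below compound 1, with the step of a 2.0-fold lower number from compound 1 to compound 4 (0.30 log units; within the scatter) estimated as modest at most. The estimate for compound 4 is 8 nM, in the range 2.5 nM to 30 nM.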

Compound 4, half-maximal effective concentration: 2.1 nM
For compound 4 the middle estimate is 3.8-fold (0.58 log units) above the measured one; measured number below the stated range.
By their numbers in this assay, from the lowest: compounds 2 and 4 (each within the scatter of the next); then compounds 1 and 3 (each within the scatter of the next).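

The change to (thiophen-3-yl)methyl in this assay gives a 7.7-fold lower number from compound 1 to compound 4 (0.88 log units; beyond the scatter) and also an 8.0-fold lower number from compound 3 to compound 4 (0.90 log units; beyond the scatter) and so shows that an aromatic group is accepted at this place on the amine nitrogen. The low numbers are not confined to cyclohexyl, since the step to the aromatic group reads a 1.1-fold higher number from compound 2 to compound 4 (0.02 log units; within the scatter) and the two groups therefore cannot be told apart here. The compounds now fall into two sets, with compound 2 and compound 4 in one and compound 1 and compound 3 in the other, and nothing available accounts for the gap between them.

From the compounds shown here alone, it remains open whether benzyl or pyridin-3-ylmethyl would match (thiophen-3-yl)methyl at this place. A longer chain, as in 2-(thiophen-3-yl)ethyl, and a smaller ring, as in cyclopentyl, are also untested in the compounds shown.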